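Oral exposure across amino substituents in the series

The compounds below may be only part of what the source reports. "The series", "measured", "known", "first", "only" and "open" are said of these compounds alone.

Measured in an ADME assay on the whole organism (plasma) for pharmacokinetics, with Rattus norvegicus as the target, with a stated time of 6 h, at a dose of 10 mg/kg by the oral route (a lower number here means less compound in the circulation, a higher number more compound in the circulation at the dose given), as area under the concentration-time curve:
- Compound 1 `CCOCCNc1nc(C)c(-c2nc3cnccc3s2)c(N[C@@H]2C[C@H](CO)[C@@H](O)[C@H]2O)n1` reads 92.1 ng.h/mL
- Compound 2 `Cc1nc(NCC2CCN(C)CC2)nc(N[C@@H]2C[C@H](CO)[C@@H](O)[C@H]2O)c1-c1nc2cnccc2s1` reads "not determined" (no result reported)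
- Compound 3 `Cc1nc(N(C)Cc2ccccc2)nc(N[C@@H]2C[C@H](CO)[C@@H](O)[C@H]2O)c1-c1nc2cnccc2s1` reads 98.5 ng.h/mL

Compound 3 (98.5 ng.h/mL) stands within the scatter of compound 1 (92.1 ng.h/mL), and compound 2 offers no number for comparison. Among the compounds with values here, the two numbers therefore mark a single level of exposure for the series so far.

The next entry is compound 4 `Cc1nc(N[C@@H](C)c2ccccc2)nc(N[C@@H]2C[C@H](CO)[C@@H](O)[C@H]2O)c1-c1nc2cnccc2s1`, which has the same atoms as compound 3, joined differently. The difference is (1-phenylethyl)amino in place of benzyl(methyl)amino on an aromatic carbon and it puts (1-phenylethyl)amino in place of benzyl(methyl)amino on an aromatic carbon, between two ring nitrogen atoms.

Within the data shown here, only one measured step bears on this position, and it is a 1.1-fold higher number from compound 1 to compound 3 (0.03 log units; within the scatter) for a change at the same aromatic carbon. Among the measured compounds shown here, that single step is thin evidence, and no measured step isolates the new stereocentre. On these data alone, no step beyond the scatter is therefore expected in this assay, although either direction remains open. The estimated step is a 1.0-fold lower number from compound 3 to compound 4 (0.02 log units; within the scatter) as the working expectation.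

For compound 4 the expected value is 95 ng.h/mL with an estimated range from 40 ng.h/mL to 220 ng.h/mL (an expectation, not a measurement).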

Compound 4, area under the concentration-time curve: 49.3 ng.h/mL
For compound 4 the middle estimate is 1.9-fold (0.28 log units) above the measured one; the range from low to high includes it.
By their numbers in this assay, from the lowest: compounds 4, 1 and 3 (each within the scatter of the next).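

In this assay, moving the same atoms from benzyl(methyl)amino to (1-phenylethyl)amino, on the aromatic carbon between two ring nitrogen atoms, gives a 2.0-fold lower number from compound 3 to compound 4 (0.30 log units; within the scatter), and replacing the 2-ethoxyethyl group on that nitrogen with 1-phenylethyl gives a 1.9-fold lower number from compound 1 to compound 4 (0.27 log units; within the scatter). Compounds 1, 3 and 4 therefore stay within the scatter of one another at this position, now across a substituent with a defined stereocentre and across both an amino nitrogen that keeps its hydrogen-bond donor, as in compound 4, and one that has none, as in compound 3. No measurement available here accounts for the size of either step.

Compound 2 has no reported number, so steps involving it cannot be read, and the series offers no reading for a side chain carrying a ring amine. On these data alone, whether the opposite configuration at the 1-phenylethyl stereocentre, or a carboxylic acid on the chain at this aromatic carbon, would move the number beyond the scatter remains open.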